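The compounds below may be only part of what the source reports. "The series", "measured", "known", "first", "only" and "open" are said of these compounds alone.

Working notes on the series. In a functional assay on the whole organism for inhibition, with Rattus norvegicus as the target (a higher number here means that more compound is needed for the effect, a lower number that less compound is needed), compound 1 `CC(C)c1ccc(OC(C)(Cc2ccccc2)C(=O)O)cc1` is the starting point. Compound 1 gives > 10 mg/kg, which is a limit and not a number (the limit of > 10 mg/kg in this assay, at which 1 of the 3 values shown sits). The change to compound 4 `CCCc1cccc(CC(C)(Oc2ccc(C(C)C)cc2)C(=O)O)c1` is propyl in place of hydrogen on an aromatic carbon, meta to a large group.

Two measured replacements of that same hydrogen bear on it. Compound 2 `Cc1ccc(CC(C)(Oc2ccc(C(C)C)cc2)C(=O)O)cc1`, with methyl, gives < 1 mg/kg, also a limit (the limit of < 1 mg/kg in this assay, at which 1 of the 3 values shown sits). The record shows an at least 10-fold lower number from compound 1 to compound 2 (1.00 log units; beyond the scatter), which is beyond the scatter. Compound 3 `CCc1ccccc1CC(C)(Oc1ccc(C(C)C)cc1)C(=O)O`, with ethyl, gives 5 mg/kg. The record shows an at least 2.0-fold lower number from compound 1 to compound 3 (0.30 log units; that floor lies within the scatter), a floor that lies within the scatter. The two substituted compounds do not agree, since the record also shows an at least 5.0-fold higher number from compound 2 to compound 3 (0.69 log units; beyond the scatter), beyond the scatter. For the measured compounds named here, no measured compound carries propyl.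

A lower number than the limit of compound 1 is therefore expected, with a size nearer the ethyl case than the methyl case, and with wide uncertainty. The expected step is an at least 3.3-fold lower number from compound 1 to compound 4 (0.52 log units; beyond the scatter). Compound 4 is estimated at 3 mg/kg, with an expected range of 0.7 mg/kg to 10 mg/kg.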

Compound 4, dose for half-maximal effect: 1 mg/kg
Estimate against measurement, compound 4: 3.0-fold (0.48 log units) above; measured number inside the range.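

In this assay the added propyl group, on an aromatic carbon and meta to a large group, brings an at least 10-fold lower number from compound 1 to compound 4 (1.00 log units; beyond the scatter), which is beyond the scatter. This position therefore accepts a chain of three carbons with a lower number than the unsubstituted compound, something the methyl and ethyl compounds could not show. Compound 4 itself gives 1 mg/kg, a measured number, which gives the series a firm reference point at this position. The value of compound 1 is a limit and not a number, so the step from it is only a floor and its full size stays unknown: the limit of > 10 mg/kg in this assay, at which 1 of the 4 values shown sits.

Compound 4 differs from compound 2 and from compound 3 in more than one place, so the compounds shown do not separate the effect of chain length from that of the place of the group on the ring. Also open, from the compounds shown here alone, is whether a longer chain such as butyl, a branched group such as isopropyl, or an amine on the same aromatic carbon would keep the number as low as that of compound 4.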